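Replacing the Carbamate on the Ring Nitrogen of Compound 3

The source may hold more compounds than are shown below. What is called first, only, known or untested is meant among the compounds shown, and "the series" means these compounds.

Of the compounds shown here, three have been tested in a functional assay on isolated protein with Glucose-dependent insulinotropic receptor (Mus musculus) as the target, read by HTRF and cAMP accumulation, with a stated time of 45 min; on this read-out higher numbers stand for larger maximal responses and lower numbers for smaller maximal responses. Compound 1 `CC(C)(C)OC(=O)N1C[C@@H]2CC[C@H]1CN2c1ncc(OCc2ccc(S(C)(=O)=O)cc2)cn1` gives 0% in this assay and thus produces no response. Compound 2 `C[C@@H]1CN(C(=O)OC(C)(C)C)CCN1c1ncc(OCc2ccc(-n3cnnn3)cc2)cn1` gives 115% in this assay, a response somewhat larger than that of the reference agonist. Compound 3 `CC(C)OC(=O)N1CCN(c2ncc(OCc3ccncc3C#N)cn2)[C@H](C)C1` gives 77% in this assay and stands second highest of the three numbers: the nearest value, that of compound 2, lies higher by a gap beyond the usual scatter, and the furthest, that of compound 1, lies lower by a gap also beyond the scatter.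

Compound 4 `C[C@@H]1CN(c2nc(C3CC3)no2)CCN1c1ncc(OCc2ccncc2C#N)cn1` has not yet been measured. It differs from compound 3 in one place: 3-cyclopropyl-1,2,4-oxadiazol-5-yl in place of isopropoxycarbonyl on an amine nitrogen in a ring. The group that leaves carries no ring, while the group that enters brings one three-membered non-aromatic ring of carbon only and one five-membered aromatic ring with three hetero atoms. Within the data shown here, no measured pair shows this change on its own, so its effect cannot be read from the data. The expected step is a number 7 percentage points lower from compound 3 to compound 4 (within the scatter), small and within the scatter or just beyond it, leaning toward a slightly lower number. Compound 4 is therefore estimated at 70% in this assay, with a range from 35% to 105%.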

Compound 4, intrinsic activity: the largest response reached, in percent of the reference agonist's: 49%
For compound 4 the middle estimate is 21 percentage points above the measured one; measured number inside the range.
By their numbers in this assay, from the lowest: compound 1; then compound 4; then compound 3; then compound 2.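

In this assay, among these compounds, putting 3-cyclopropyl-1,2,4-oxadiazol-5-yl in place of isopropoxycarbonyl on the amine nitrogen of the six-membered ring gives a number 28 percentage points lower from compound 3 to compound 4 (beyond the scatter), the first direct reading of a change at this position. Compound 4 still gives 49%, so the receptor still responds without the isopropoxycarbonyl group at this nitrogen, although the largest response reached is clearly smaller than with that group in place. Nothing available explains why the maximal response falls with this exchange.

The five-membered aromatic ring and the cyclopropyl on it enter together, and the compounds shown do not reveal how much of the lower response belongs to each part. On these data alone, it also remains open how the maximal response would change with a methyl or an isopropyl in place of the cyclopropyl on the same ring, or with a simple acetyl in place of the whole group on the ring nitrogen.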